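This account rests on a few compounds, and the source may have more. Where it says the series, first, only, none or still open, it means among the compounds named here.

In a functional assay on HepG2 cells (Homo sapiens) for cytotoxicity, read by MTT assay, with a stated time of 72 h (on this read-out lower numbers stand for stronger inhibition and higher numbers for weaker inhibition), compound 1 `COc1ccc(-n2ccc(=O)c(C(=O)Nc3ccc(Oc4ccnc5[nH]ccc45)cc3)n2)cc1` gives 50800 nM. Compound 2 `O=C(Nc1ccc(Oc2ccnc3[nH]ccc23)c(F)c1)c1nn(-c2ccc(Cl)cc2)ccc1=O` reaches only the limit of this assay, > 60000 nM, so for compound 2 a limit rather than a number is known. Compound 3 `COc1ccc(-n2ccc(=O)c(C(=O)Nc3ccc(Oc4ccnc5[nH]ccc45)c(F)c3)n2)cc1` is still to be measured in this assay. It differs from compound 2 in one place: methoxy in place of chloro on an aromatic carbon. Within the data shown here, no measured pair isolates this change, and compound 1, which also carries the methoxy group, sits near the limit at which compound 2 stands (the limit of > 60000 nM in this assay, at which 1 of the 2 values shown sits). Compound 3 is therefore expected to show a step of about an at least 1.0-fold lower number from compound 2 to compound 3 (0.03 log units; that floor lies within the scatter), near the edge of what this assay reports, estimated at 55000 nM within 25000 nM to 120000 nM.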

Compound 3, half-maximal inhibitory concentration: > 60000 nM
Compound 3: no number, only a limit (the forecaster's own chance of this, stated with the estimate: 45%); at least 1.0-fold (0.03 log units) between middle value and limit.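

In this assay compound 3 gives > 60000 nM, which is a limit of the assay and not a number. Compound 2 also stands at a limit, so the swap of 4-chlorophenyl to 4-methoxyphenyl cannot be read, and most of the compounds now sit there: the limit of > 60000 nM in this assay, at which 2 of the 3 values shown sit.

Fluoro in place of hydrogen on an aromatic carbon gives an at least 1.1-fold higher number from compound 1 to compound 3 (0.07 log units; that floor lies within the scatter), so the true size of that change stays unknown. As far as these compounds go, whether an amine or a carboxylic acid at this position would give a measurable number remains open.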